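A Larger Hydroxyalkyl Amide on the Shared Core

The compounds below may be only part of what the source reports. "The series", "measured", "known", "first", "only" and "open" are said of these compounds alone.

Of the compounds shown here, three on one shared core have been measured in an assay on cells for positive allosteric modulation of Cystic fibrosis transmembrane conductance regulator variant F508del (Homo sapiens), with stated times of 10 min and 7 s, in the presence of a further agent that is not named here; a higher number here means that more compound is needed for the effect, a lower number that less compound is needed. Compound 1 `CC1(C)Cc2c(sc(NC(=O)c3cn[nH]c3)c2C(N)=O)C(C)(C)O1` gives 125 nM. Compound 2 `CC1(C)Cc2c(sc(NC(=O)Cc3ccn[nH]3)c2C(N)=O)C(C)(C)O1` gives 136 nM, and the change a 1.1-fold higher number from compound 1 to compound 2 (0.04 log units; within the scatter) is too small to read anything into. Compound 3 `CC1(C)Cc2c(sc(NC(=O)C(C)(C)O)c2C(N)=O)C(C)(C)O1` gives 16 nM, the lowest of the three numbers, and it is set apart from both others by a 7.8-fold lower number from compound 1 to compound 3 (0.89 log units; beyond the scatter) and an 8.5-fold lower number from compound 2 to compound 3 (0.93 log units; beyond the scatter). Compound 4 `CC1(C)Cc2c(sc(NC(=O)[C@H](O)C(C)(C)C)c2C(N)=O)C(C)(C)O1` is not yet measured. It differs from compound 3 in one place: 1-hydroxy-2,2-dimethylpropyl in place of 1-hydroxy-1-methylethyl on a carbonyl carbon. Within the data shown here, the two steps that lead to compound 3 each replace a ring-bearing group with the 1-hydroxy-1-methylethyl group; they show that the hydroxyalkyl arrangement, which compound 4 keeps, goes with the lower number, but no measured pair compares two hydroxyalkyl groups of different size. Among the measured compounds shown here, with no direct counterpart, the expected change in this assay from compound 3 to compound 4 is a 1.4-fold higher number from compound 3 to compound 4 (0.14 log units; within the scatter), a step not clearly beyond the scatter. Compound 4 is therefore estimated at 22 nM, with a range from 7 nM to 70 nM.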

Compound 4, half-maximal effective concentration: 127 nM
Compound 4: the middle estimate sits 5.8-fold (0.76 log units) below what was measured; measured number outside the range, above it.
By their numbers in this assay, from the lowest: compound 3; then compounds 1, 4 and 2 (each within the scatter of the next).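

In this assay, among these compounds, this is the first comparison of two hydroxyalkyl groups on this carbonyl carbon, and it shows that keeping a hydroxyalkyl group does not by itself keep the low number: the change to the larger 1-hydroxy-2,2-dimethylpropyl group gives a 7.9-fold higher number from compound 3 to compound 4 (0.90 log units; beyond the scatter) at this position. The same change cancels the gap that set compound 3 apart from the ring-bearing amides, as a 1.0-fold higher number from compound 1 to compound 4 (0.01 log units; within the scatter) and a 1.1-fold lower number from compound 2 to compound 4 (0.03 log units; within the scatter) place compound 4 level with both. No measured evidence here accounts for the change.

The compounds shown cannot separate the effect of group size from that of the defined stereocentre, so the opposite stereoisomer of compound 4 remains an open comparison. They also leave open how an intermediate group such as 1-hydroxy-1-methylpropyl, or an amine in place of the hydroxyl, would behave at this position.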